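The source may report more compounds than this note shows. Statements on the series, on what has been measured and on what is new or still open speak of the compounds shown alone.

Measured so far in a physicochemical assay for lipophilicity; a lower number here means a more polar compound, a higher number a more lipophilic compound:
compound 1, `CN1CCN(CCCS(=O)(=O)c2ccc3nc(NC(=O)NC(=O)c4cccc(-n5cccn5)c4Cl)sc3c2)CC1` — 1.6
compound 2, `CCc1ccc(Cl)c(C(=O)NC(=O)Nc2nc3ccc(S(=O)(=O)CCCN4CCN(C)CC4)cc3s2)c1` — 2.9
compound 3, `Cc1cc(C)n(-c2ccc(Cl)c(C(=O)NC(=O)Nc3nc4ccc(S(=O)(=O)CCCN5CCN(C)CC5)cc4s3)c2)n1` — 2.5

Compound 3 holds the second highest of the three numbers in this assay. Its nearest neighbour is compound 2; the step of a number 0.40 log units lower from compound 2 to compound 3 (beyond the scatter) is beyond the scatter. The furthest is compound 1, and the two values lie well apart, also beyond the scatter.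

Compound 4, `CN1CCN(CCCS(=O)(=O)c2ccc3nc(NC(=O)NC(=O)c4cc(-n5cccc5)ccc4Cl)sc3c2)CC1`, is not yet measured. It differs from compound 3 by 1H-pyrrol-1-yl in place of 3,5-dimethyl-1H-pyrazol-1-yl on an aromatic carbon; the group that leaves is counted as larger and carries two acceptors, the group that enters is smaller and carries one.

Among the compounds with values here, two measured steps bear on this. The step of a number 1.30 log units higher from compound 1 to compound 2 (beyond the scatter) was large and changed both the group and its place on the ring, so it cannot be read cleanly. The step of a number 0.40 log units lower from compound 2 to compound 3 (beyond the scatter) was modest and shows a dimethylpyrazolyl in place of an ethyl lowering the number. Removing the two methyls and one ring nitrogen pulls in opposite directions, so the net step is expected to be small. Compound 4 is therefore expected to give 2.3 in this assay, between 1.8 and 2.8, which is an estimated step of a number 0.20 log units lower from compound 3 to compound 4 (within the scatter) from compound 3.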

Compound 4, distribution coefficient: 2.6
Estimate against measurement, compound 4: 0.30 log units below, within the range that was stated.
By their numbers in this assay, from the lowest: compound 1; then compounds 3, 4 and 2 (each within the scatter of the next, the first and the last beyond it).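

In this assay the step of a number 0.10 log units higher from compound 3 to compound 4 (within the scatter) and the step of a number 0.30 log units lower from compound 2 to compound 4 (within the scatter) both stay within the scatter, so at this position, para to the chloro group, 1H-pyrrol-1-yl cannot be told apart from either 3,5-dimethyl-1H-pyrazol-1-yl or ethyl, although those two groups do stand apart from each other. The step of a number 1.00 log units higher from compound 1 to compound 4 (beyond the scatter) lies beyond the scatter, so a five-membered aromatic ring on this phenyl does not by itself go with the value of compound 1, though ring and ring place change together in that step. No measurement at hand gives a cause for these steps.

On these data alone, whether the ring or its place carries the gap to compound 1 stays open. Also open, as far as these compounds go, is how an amine or a carboxylic acid para to the chloro group would read in this assay against these groups.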